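The source may report more compounds than this note shows. Statements on the series, on what has been measured and on what is new or still open speak of the compounds shown alone.

In a functional assay on HeLa cells (Homo sapiens) for inhibition, read by MTT assay, with a stated time of 72 h (a lower number here means a stronger inhibitor, a higher number a weaker inhibitor), compound 2 `COc1cc(OC)c(-c2cc(=O)c3cc(Cl)ccc3o2)cc1OC` stands only at a limit, > 150000 nM. Compound 1 `COc1cc(OC)c(OC)cc1/C=C/C(=O)c1ccc(-c2c[nH]cn2)cc1` is likewise a limit, > 150000 nM. Compound 3 `COc1cc(OC)c(OC)cc1/C=C/C(=O)c1ccc(C)cc1` gives a real number, 42200 nM. The change under study leads to compound 4 `COc1cc(OC)c(-c2cc(=O)c3cc(O)ccc3o2)cc1OC`, with hydroxy in place of chloro on an aromatic carbon. Going by the values given here, the one measured step, an at least 3.5-fold lower number from compound 1 to compound 3 (0.55 log units; beyond the scatter), is a different replacement on a different core, so it offers only a rough scale. Starting from a limit, only a move to a lower number could show in this assay, and a modest one is expected: an at least 1.3-fold lower number from compound 2 to compound 4 (0.13 log units; that floor lies within the scatter). Compound 4 is estimated at 110000 nM, within a range of 35000 nM to 220000 nM.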

Compound 4, half-maximal inhibitory concentration: > 150000 nM
Compound 4: no number, only a limit; the forecaster's own chance of this, stated with the estimate: 50%; middle value at least 1.3-fold (0.13 log units) from the limit.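

Compound 2 and compound 4 both stand at a limit in this assay, so the step between them cannot be read: the limit of > 150000 nM in this assay, at which 3 of the 4 values shown sit.

The compounds shown leave open whether hydroxy in place of chloro on the shared core changes inhibition in this assay at all.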